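Swapping Methoxy for Fluoro on the Sulfonyl Aryl Ring

A few compounds are considered here, and "the series" means these few. Any claim that something is new, unique, unknown or untested is made for them only; others in the source may bear on it.

Two compounds of this series have been run in an ADME assay on microsomes from liver (Homo sapiens) for metabolic stability, tested at 2.5 uM; on this read-out lower numbers stand for slow clearance and higher numbers for fast clearance. Compound 1 `Cc1ccc(S(=O)(=O)c2cnc3cc(F)ccc3c2-c2ccc(F)cc2)cc1C` gives 9.25 mL/min, whereas compound 2 `COc1ccc(S(=O)(=O)c2cnc3cc(F)ccc3c2-c2ccc(F)cc2)cc1Cl` gives 1.29 mL/min, the lower of the two numbers; the step between them is a 7.2-fold lower number from compound 1 to compound 2 (0.86 log units; beyond the scatter), which lies beyond the scatter. The next compound, compound 3 `O=S(=O)(c1ccc(F)c(Cl)c1)c1cnc2cc(F)ccc2c1-c1ccc(F)cc1`, is derived from compound 2 by fluoro in place of methoxy on an aromatic carbon.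

Within the data shown here, no measured pair repeats this exchange. Among the measured compounds shown here, the only step in hand, from 3,4-dimethylphenyl to 3-chloro-4-methoxyphenyl on a sulfonyl sulfur, alters the same ring but in a different way, so it shows merely that substituents on this ring can move the number well beyond the scatter. Taking that as the only guide, a shift upward from compound 2, partway back toward compound 1, of the size a 2.3-fold higher number from compound 2 to compound 3 (0.37 log units; beyond the scatter) is expected, though with little confidence. Compound 3 is therefore estimated to give 3 mL/min in this assay, within a range from 1.2 mL/min to 8 mL/min.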

Compound 3, intrinsic clearance in a liver preparation (reported as CLH), per the amount of preparation that the assay uses: 0.69 mL/min
Beside the measured number, compound 3's estimate is 4.3-fold (0.64 log units) above it; measured number outside the range, below it.
By their numbers in this assay, from the lowest: compounds 3 and 2 (each within the scatter of the next); then compound 1.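

In this assay, fluoro in place of methoxy on this aromatic carbon, ortho to a chloro group and para to a large group, gives a 1.9-fold lower number from compound 2 to compound 3 (0.27 log units; within the scatter) and so does not separate the two compounds. The earlier step changed two places on the ring together, whereas this one changes a single group, and it shows that the methoxy group can be exchanged for the smaller fluoro group with the number staying within the scatter of compound 2. Against the 3,4-dimethylphenyl ring, the 3-chloro-4-fluorophenyl ring gives a 13-fold lower number from compound 1 to compound 3 (1.13 log units; beyond the scatter) and so stays far from compound 1, which means that a low number here does not rest on the methoxy group alone, although no accompanying measurement shows what lies behind these numbers.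

On these data alone, how much of the distance from compound 1 belongs to the chloro group and how much to the group para to the large group stays open, since both places differ in each step from compound 1. Also open, as far as these compounds go, is how a nitrile, an amine or a longer ether chain on this same carbon would read in this assay when the chloro group is kept.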